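Removing the nitrobenzyl arm: from compound 3 to compound 4

The source may hold more compounds than are shown below. What is called first, only, known or untested is meant among the compounds shown, and "the series" means these compounds.

Of the compounds shown here, three sharing one core have been tested in a functional assay with Mus musculus as the target; a higher number here means that more compound is needed for the effect, a lower number that less compound is needed. Compound 3, `Nc1nc(O)c2c(n1)n(C1OC(CO)[C@@H](O)[C@H]1O)c(=O)n2Cc1ccc([N+](=O)[O-])cc1`, gives 50 uM; compound 1, `C=CCn1c(=S)n([C@@H]2O[C@H](CO)[C@H]3OC(C)(C)O[C@H]32)c2nc(N)nc(O)c21`, gives 45 uM, a number within the scatter of compound 3; compound 2, `COc1ccc(Cn2c(=O)n(C3OC(CO)[C@@H](O)[C@H]3O)c3nc(N)nc(O)c32)cc1`, gives 2 uM, far from both. Within the data shown here, the one single-point step measured, a 25-fold higher number from compound 2 to compound 3 (1.40 log units; beyond the scatter), is large. Compound 4, `Cn1c(=O)n(C2OC(CO)[C@@H](O)[C@H]2O)c2nc(N)nc(O)c21`, differs from compound 3 by hydrogen in place of 4-nitrophenyl on a saturated chain carbon bound to an aromatic nitrogen. Among the measured compounds shown here, no measured step removes the whole aryl group, so that step bears only indirectly: it shows that this arm matters greatly, in either direction. Compound 4 is therefore expected near the middle of the spread, with a wide range, a 3.3-fold lower number from compound 3 to compound 4 (0.52 log units; beyond the scatter). The estimate for compound 4 is 15 uM, between 2 uM and 100 uM.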

Compound 4, concentration for half-maximal effect: 120 uM
Compound 4: the middle estimate sits 8.0-fold (0.90 log units) below what was measured; measured number above the stated range.
By their numbers in this assay, from the lowest: compound 2; then compounds 1 and 3 (each within the scatter of the next); then compound 4.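

Cutting the arm back to methyl raises the number in both cases, with a 2.4-fold higher number from compound 3 to compound 4 (0.38 log units; beyond the scatter) and a 60-fold higher number from compound 2 to compound 4 (1.78 log units; beyond the scatter) for the same kind of change. Both compounds with an aryl arm therefore need less compound than the methyl compound, so even the 4-nitrophenyl arm gives some gain over hydrogen. The modest step against the large one shows that the group on the ring sets how much the arm gives.

As far as these compounds go, what a plain benzyl, a longer chain such as propyl or an amine on the ring would give at this position stays open. Nothing available explains why the arm acts this way.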